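Cytotoxicity notes on compounds 1 to 3

The compounds below may be only part of what the source reports. "The series", "measured", "known", "first", "only" and "open" are said of these compounds alone.

Measured so far:
compound 1, `O=c1[nH]cc(S(=O)(=O)Nc2cccc(-c3cn(-c4ccccc4)nn3)c2)c(=O)[nH]1`: > 100000 nM
compound 2, `O=c1[nH]cc(S(=O)(=O)Nc2cccc(-c3cn(-c4cccc(F)c4)nn3)c2)c(=O)[nH]1`: "not toxic" (no number reported)

In an ADME assay on L02 cells (Homo sapiens) for cytotoxicity, read by MTT assay, with a stated time of 24 h (a lower number here means that less compound is tolerated, a higher number that more compound is tolerated), compound 1 reaches only the limit of the measurement, > 100000 nM, which is a limit and not a number. Compound 2 is recorded in this assay as "not toxic" (no number reported), without any number. Among the measured compounds shown here, compound 2 therefore stands without a single value, and the one other value shown is a limit (the limit of > 100000 nM in this assay, at which 1 of the 2 values shown sits), so no ordering within the pair can be read.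

Compound 3, `O=c1[nH]cc(S(=O)(=O)Nc2cccc(-c3cn(-c4cccc(Cl)c4)nn3)c2)c(=O)[nH]1`, remains to be measured in this assay. It differs from compound 2 by chloro in place of fluoro on an aromatic carbon, meta to a large group. With both measured compounds at or beyond tolerance, no step beyond the scatter is expected in this assay in either direction. Compound 3 is expected to give 100000 nM in this assay, with a range of 30000 nM to 300000 nM, most likely again reported only as a limit.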

Compound 3, half-maximal cytotoxic concentration: 8330 nM
Beside the measured number, compound 3's estimate is 12-fold (1.08 log units) above it, outside the stated range (below it).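

In this assay, this position, meta to a large group, proves sensitive to substitution: chloro in place of hydrogen brings an at least 12-fold lower number from compound 1 to compound 3 (1.07 log units; beyond the scatter). Substitution here can therefore bring cytotoxicity into measurable range, which compound 1 and compound 2 alone did not show, and the size of the step is only a bound: the limit of > 100000 nM in this assay, at which 1 of the 3 values shown sits. The step between fluoro and chloro cannot be read, as compound 2 carries no number, so the two halogens can be set apart only by the words "not toxic" against a measured value.

From the compounds shown here alone, it remains open whether this effect is particular to chloro or extends to other groups at the same place, such as bromo, methyl or methoxy. Also open, going by these compounds, is whether chloro elsewhere on the same ring gives a similar number.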